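Fluoro on the anilino ring: the step to compound 4

The source may hold more compounds than are shown below. What is called first, only, known or untested is meant among the compounds shown, and "the series" means these compounds.

compound 1 `CN(C)C(=O)c1cc2cnc(Nc3ccc(NC(=O)C4(C(=O)Nc5ccccc5)CC4)cc3)nc2n1C1CCCC1` — 58%
compound 2 `CN(C)C(=O)c1cc2cnc(Nc3ccc(NC(=O)C4(C(=O)Nc5ccc(F)cc5)CC4)cc3F)nc2n1C1CCCC1` — 6.6%
compound 3 `CN(C)C(=O)c1cc2cnc(Nc3ccc(NC(=O)C4(C(=O)Nc5cccc(F)c5)CC4)cc3)nc2n1C1CCCC1` — 29.7%

In a functional assay on SiHa cells (Homo sapiens) for inhibition, read by CCK-8 assay, with a stated time of 72 h, tested at 1 uM (on this read-out higher numbers stand for more inhibition of growth at the one concentration tested and lower numbers for less inhibition of growth), compound 1 gives 58%, the highest of the three numbers, with compound 3 nearest and compound 2 furthest from it. Within the data shown here, the single measured step is a number 28.3 percentage points lower from compound 1 to compound 3 (beyond the scatter).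

Compound 4 `CN(C)C(=O)c1cc2cnc(Nc3ccc(NC(=O)C4(C(=O)Nc5ccc(F)cc5)CC4)cc3)nc2n1C1CCCC1` differs from compound 1 by fluoro in place of hydrogen on an aromatic carbon. The step from compound 1 to compound 3 is the one that bears on this change, the same kind of substituent entering the same ring at another carbon, and it was a modest drop beyond the scatter. Among the measured compounds shown here, compound 2, which carries this fluoro together with a second fluoro on the other ring, gives 6.6%, but no single step joins it to compound 1. A drop of comparable size is therefore expected for compound 4: a number 31 percentage points lower from compound 1 to compound 4 (beyond the scatter). In this assay compound 4 is estimated at 27%, within 8% to 48%.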

Compound 4, percent growth inhibition at one concentration: 36.5%
Estimate against measurement, compound 4: 9.5 percentage points below; the range from low to high includes it.
By their numbers in this assay, from the lowest: compound 2; then compounds 3 and 4 (each within the scatter of the next); then compound 1.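

In this assay, moving to the 4-fluorophenyl group also lowers inhibition, a number 21.5 percentage points lower from compound 1 to compound 4 (beyond the scatter), so a fluoro on this ring lowers the number at both carbons shown. The choice between those two carbons sets no order, a number 6.8 percentage points higher from compound 3 to compound 4 (within the scatter). The fluoro on the other ring now stands as a step of its own, a number 29.9 percentage points higher from compound 2 to compound 4 (beyond the scatter), and the two fluoro steps match in size: the same change on two cores in this assay, a number 28.3 percentage points lower (beyond the scatter) from compound 1 to compound 3 and a number 29.9 percentage points lower (beyond the scatter) from compound 4 to compound 2, 1.6 percentage points apart, within the scatter of two such steps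

As far as these compounds go, whether a methoxy, a chloro or an amine at this carbon would behave like fluoro remains open. The cause of either loss also remains open.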